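Dropping a methoxy from the indole core: what to expect

The source may hold more compounds than are shown below. What is called first, only, known or untested is meant among the compounds shown, and "the series" means these compounds.

Compounds measured so far:
- compound 1, `COc1ccc(-c2[nH]c3ccccc3c2/C=C(\C#N)S(=O)(=O)c2ccccc2)cc1`: 399 nM
- compound 2, `CC(=O)/C(=C\c1c(-c2ccccc2)[nH]c2ccccc12)S(=O)(=O)c1ccccc1`: 754 nM
- compound 3, `COc1ccc2[nH]c(-c3ccccc3)c(/C=C(\C#N)S(=O)(=O)c3ccccc3)c2c1`: 3700 nM

All three share a core in which an indole bears a vinyl sulfone arm, and they were tested in a functional assay on HCT-116 cells (Homo sapiens) for inhibition, read by sulforhodamine B assay, with a stated time of 48 h; a higher number here means a weaker inhibitor of growth, a lower number a stronger inhibitor of growth. Compound 3 gives 3700 nM, the highest number of the three. The gap to compound 2, which gives 754 nM, lies beyond the usual scatter, and the gap to compound 1, which gives 399 nM, is larger still. Compound 3 is thus the weakest growth inhibitor among the measured compounds.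

Compound 4, `N#C/C(=C\c1c(-c2ccccc2)[nH]c2ccccc12)S(=O)(=O)c1ccccc1`, has not yet been measured. It differs from compound 3 in one place: hydrogen in place of methoxy on an aromatic carbon. Put simply, compound 4 is the parent with no substituent on that ring of the core, while the nitrile and the phenylsulfonyl arm stay unchanged.

For the measured compounds named here, no pair among the measured compounds differs in exactly this way, so the step cannot be read off directly. Since the unsubstituted arrangement of the core in compound 1 and compound 2 goes with the lower numbers, the expectation is that compound 4 moves toward them, a step estimated as a 5.3-fold lower number from compound 3 to compound 4 (0.72 log units; beyond the scatter). For compound 4 the estimated value in this assay is 700 nM, with a likely range from 200 nM to 2500 nM.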

Compound 4, concentration for 50% growth inhibition: 2000 nM
Estimate against measurement, compound 4: 2.9-fold (0.46 log units) below, within the range that was stated.
By their numbers in this assay, from the lowest: compounds 1 and 2 (each within the scatter of the next); then compounds 4 and 3 (each within the scatter of the next).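

In this assay, the methoxy on the core carries little weight: replacing it with hydrogen gives a 1.9-fold lower number from compound 3 to compound 4 (0.27 log units; within the scatter), so compound 3 and compound 4 cannot be told apart. The same kind of swap at the methoxy position of compound 1 does register, giving a 5.0-fold higher number from compound 1 to compound 4 (0.70 log units; beyond the scatter), so among these compounds the effect of removing a methoxy depends on where it stands. The arm matters as well, since nitrile in place of acetyl gives a 2.7-fold higher number from compound 2 to compound 4 (0.42 log units; beyond the scatter), a modest step that shows the group on the double-bonded chain carbon can also shift the number while the rest of the molecule stays the same.

As far as these compounds go, it remains open whether other groups on that aromatic carbon of the core, such as an amine or an ethoxy chain, would also leave the number within the scatter, and whether an amide on the arm would behave like the acetyl or the nitrile. Nothing measured here explains why any of these steps has the size it does.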